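Fluoro in place of hydrogen on compound 2

The source may report more compounds than this note shows. Statements on the series, on what has been measured and on what is new or still open speak of the compounds shown alone.

Measured in a functional assay on A549 cells (Homo sapiens) for inhibition, read by MTT assay, with a stated time of 72 h; a higher number here means a weaker inhibitor, a lower number a stronger inhibitor:
- compound 1 `C/C=C\C(=O)Nc1cc(Nc2nc3c(c(-c4cn(C)c5ccccc45)n2)CS(=O)(=O)CC3)c(OC)cc1N(C)CCN(C)C` gives 4260 nM
- compound 2 `CC/C=C\C(=O)Nc1cc(Nc2nc3c(c(-c4cn(C)c5ccccc45)n2)CS(=O)(=O)CC3)c(OC)cc1N(C)CCN(C)C` gives 1350 nM
- compound 3 `CCC/C=C\C(=O)Nc1cc(Nc2nc3c(c(-c4cn(C)c5ccccc45)n2)CS(=O)(=O)CC3)c(OC)cc1N(C)CCN(C)C` gives 57 nM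

Compound 2 holds the second highest of the three numbers in this assay. Its nearest neighbour lies at a 3.2-fold lower number from compound 1 to compound 2 (0.50 log units; beyond the scatter), and the furthest at a 24-fold lower number from compound 2 to compound 3 (1.37 log units; beyond the scatter).

Compound 4 `CC/C=C\C(=O)Nc1cc(Nc2nc3c(c(-c4cn(C)c5ccc(F)cc45)n2)CS(=O)(=O)CC3)c(OC)cc1N(C)CCN(C)C` keeps the chain of compound 2 and turns 1-methyl-1H-indol-3-yl into 5-fluoro-1-methyl-1H-indol-3-yl: fluoro in place of hydrogen on an aromatic carbon.

The measured steps, the widest being a 75-fold lower number from compound 1 to compound 3 (1.87 log units; beyond the scatter), all alter the saturated chain. None places fluoro in place of hydrogen on an aromatic carbon, so none bears directly on this change, and their sizes cannot be carried over. Within the data shown here, the series holds no measured example of this change, so no shift beyond the scatter is expected in this assay, and either direction remains open.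

The expected outcome is a 1.1-fold lower number from compound 2 to compound 4 (0.05 log units; within the scatter).

Compound 4 is estimated at 1200 nM, with an expected range of 450 nM to 3200 nM.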

Compound 4, half-maximal inhibitory concentration: 5830 nM
Compound 4: the middle estimate sits 4.9-fold (0.69 log units) below what was measured; the measured number lies above the stated range.
By their numbers in this assay, from the lowest: compound 3; then compound 2; then compounds 1 and 4 (each within the scatter of the next).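

In this assay, the aromatic carbon of the 1-methyl-1H-indol-3-yl group is not a silent position: fluoro in place of hydrogen there gives a 4.3-fold higher number from compound 2 to compound 4 (0.64 log units; beyond the scatter). This is the first step shown away from the saturated chain, and it shows that this part of the molecule also shifts the number beyond the scatter, here towards weaker inhibition, whereas every chain step shown runs to a lower number. No measured finding on hand accounts for this shift.

The compounds shown do not tell whether the fluoro change costs as much on the longer chain of compound 3. Nor do they tell whether chloro, methoxy or nitrile on the same aromatic carbon would give a number like that of compound 4.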